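Halogen swap on the benzyl ring of compound 2

The compounds below may be only part of what the source reports. "The series", "measured", "known", "first", "only" and "open" are said of these compounds alone.

compound 1 `O=C(NC1CCN(Cc2cccc(Cl)c2)CC1)c1cccc2ccccc12`: 116 nM
compound 2 `O=C(NC1CCN(Cc2ccc(Cl)cc2)CC1)c1cccc2ccccc12`: 43 nM
compound 3 `O=C(NC1CCN(Cc2cccc(Br)c2)CC1)c1cccc2ccccc12`: 66 nM

In an assay on isolated protein for displacement of a labelled ligand from D(4) dopamine receptor (Homo sapiens) (on this read-out higher numbers stand for weaker inhibition and lower numbers for stronger inhibition), compound 2 gives the lowest of the three numbers; compound 3 lies within the scatter of it, the step being a 1.5-fold higher number from compound 2 to compound 3 (0.19 log units; within the scatter), whereas the step of a 2.7-fold lower number from compound 1 to compound 2 (0.43 log units; beyond the scatter) lies beyond the scatter. Compound 4 `O=C(NC1CCN(Cc2ccc(Br)cc2)CC1)c1cccc2ccccc12` differs from compound 2 by bromo in place of chloro on an aromatic carbon. Among the measured compounds shown here, the one measured step that bears on this exchange is a 1.8-fold lower number from compound 1 to compound 3 (0.24 log units; within the scatter), the same halogen swap made on compound 1, and it stays within the scatter. Compound 4 is therefore expected to land close to compound 2, with at most a small move toward a lower number, estimated as a 1.2-fold lower number from compound 2 to compound 4 (0.09 log units; within the scatter). For compound 4 the expected value is 35 nM, with a range from 15 nM to 90 nM.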

Compound 4, inhibition constant: 44 nM
Estimate against measurement, compound 4: 1.3-fold (0.10 log units) below; measured number inside the range.
By their numbers in this assay, from the lowest: compounds 2, 4, 3 and 1 (each within the scatter of the next, the first and the last beyond it).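

With the halogen para to a large group, bromo in place of chloro gives a 1.0-fold higher number from compound 2 to compound 4 (0.01 log units; within the scatter), so the exchange can now be read directly on this ring. Against the other two bromo and chloro compounds, the picture is split: a 1.5-fold lower number from compound 3 to compound 4 (0.18 log units; within the scatter), whereas a 2.6-fold lower number from compound 1 to compound 4 (0.42 log units; beyond the scatter). The halogen swap reads alike on both cores: the same change on two cores in this assay, a 1.8-fold lower number (0.24 log units; within the scatter) from compound 1 to compound 3 and a 1.0-fold higher number (0.01 log units; within the scatter) from compound 2 to compound 4, 1.8-fold (0.25 log units) apart, within the scatter of two such steps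

Still open, on these data alone, is whether fluoro, methoxy, a nitrile or an amine in place of the halogen would hold the number at this position. Also open, as far as these compounds go, is whether the same holds on a core other than the one shared here.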